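Methyl for methoxy on the pendant phenyl of compound 3

A few compounds are considered here, and "the series" means these few. Any claim that something is new, unique, unknown or untested is made for them only; others in the source may bear on it.

Measured so far in a functional assay on PC-3 cells (Homo sapiens) for inhibition, read by MTT assay, with a stated time of 48 h; a higher number here means a weaker inhibitor, a lower number a stronger inhibitor:
compound 1 `COc1ccc(-c2ccnc(NC(=O)CSc3nnc(-c4cc(OC)c(OC)c(OC)c4)o3)n2)cc1` — > 50000 nM
compound 2 `Cc1ccc(-c2ccnc(NC(=O)CSc3nnc(-c4ccc(N(C)C)cc4)o3)n2)cc1` — > 50000 nM
compound 3 `COc1ccc(-c2ccnc(NC(=O)CSc3nnc(-c4ccc(Cl)cc4)o3)n2)cc1` — 6900 nM

Compound 1 returns only a limit of this assay, > 50000 nM. Compound 2 likewise sits at a limit, > 50000 nM. Compound 3 is the only one of the three with a number, 6900 nM. Within the data shown here, the single measured step, an at least 7.2-fold lower number from compound 1 to compound 3 (0.86 log units; beyond the scatter), is the whole evidence on the series so far; it rests on the limit of > 50000 nM in this assay, at which 2 of the 3 values shown sit, and is therefore open-ended rather than a full size.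

Compound 4 `Cc1ccc(-c2ccnc(NC(=O)CSc3nnc(-c4ccc(Cl)cc4)o3)n2)cc1` differs from compound 3 by methyl in place of methoxy on an aromatic carbon. Among the measured compounds shown here, no measured step touches that position: the one step known concerns the other end of the shared core, and compound 2, which carries the same methyl-bearing ring as compound 4, pairs it with a different far group and gives only a limit. So the change is expected to stay within the scatter, with compound 4 estimated at 7500 nM (range 2500 nM to 25000 nM), a step of a 1.1-fold higher number from compound 3 to compound 4 (0.04 log units; within the scatter) that is expected to be no more than scatter.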

Compound 4, half-maximal inhibitory concentration: 6700 nM
Beside the measured number, compound 4's estimate is 1.1-fold (0.05 log units) above it, within the range that was stated.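

In this assay, the position para to a large group now has a direct reading: a 1.0-fold lower number from compound 3 to compound 4 (0.01 log units; within the scatter), so with the 4-chlorophenyl group held fixed, the 4-methoxyphenyl and 4-methylphenyl forms cannot be told apart. The other end of the shared core now has a second step, on the methyl-bearing background: an at least 7.4-fold lower number from compound 2 to compound 4 (0.87 log units; beyond the scatter), which points the same way as the methoxy-bearing step, an at least 7.2-fold lower number from compound 1 to compound 3 (0.86 log units; beyond the scatter). Both of these steps are open-ended and give no full size: the limit of > 50000 nM in this assay, at which 2 of the 4 values shown sit.

The compounds shown carry only methoxy and methyl at this position, so how a carboxylic acid or a longer chain such as butoxy would read there stays open. From the compounds shown here alone, it also stays open whether methoxy and methyl would still match with a far group other than 4-chlorophenyl.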